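This account rests on a few compounds, and the source may have more. Where it says the series, first, only, none or still open, it means among the compounds named here.

Measured in a functional assay on A549 cells (Homo sapiens) for antiproliferative activity, read by sulforhodamine B assay, with a stated time of 48 h; on this read-out higher numbers stand for weaker inhibition and lower numbers for stronger inhibition:
compound 1 `COc1cccc(/C=C/C(=O)C(=Cc2ccc(F)cc2)C(=O)/C=C/c2cccc(OC)c2OC)c1OC`: 340 nM
compound 2 `COc1cccc(/C=C/C(=O)C(=Cc2cc(OC)c(OC)c(OC)c2)C(=O)/C=C/c2cccc(OC)c2OC)c1OC`: 230 nM
compound 3 `COc1ccc(OC)c(/C=C/C(=O)C(=Cc2ccc(O)c(OC)c2)C(=O)/C=C/c2cc(OC)ccc2OC)c1`: 190 nM

The three values lie within the scatter of one another, so compound 3 stands level with compound 1 and compound 2. Compound 4 `COc1ccc(OC)c(/C=C/C(=O)C(=Cc2cc(OC)c(O)c(OC)c2)C(=O)/C=C/c2cc(OC)ccc2OC)c1` differs from compound 3 by methoxy in place of hydrogen on an aromatic carbon, turning 4-hydroxy-3-methoxyphenyl into 4-hydroxy-3,5-dimethoxyphenyl. Among the measured compounds shown here, only one measured step bears on this, a different exchange on the same chain carbon and with other groups elsewhere: a 1.5-fold lower number from compound 1 to compound 2 (0.17 log units; within the scatter). No step beyond the scatter is therefore expected in this assay. The estimated change is a 1.1-fold higher number from compound 3 to compound 4 (0.02 log units; within the scatter). Compound 4 is expected at 200 nM, within an estimated range of 90 nM to 450 nM.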

Compound 4, half-maximal inhibitory concentration: 190 nM
Estimate against measurement, compound 4: 1.1-fold (0.02 log units) above, and the stated range covers the measured number.
By their numbers in this assay, from the lowest: compounds 3, 4, 2 and 1 (each within the scatter of the next).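

In this assay, methoxy in place of hydrogen on an aromatic carbon, ortho to a hydroxy group, turns 4-hydroxy-3-methoxyphenyl into 4-hydroxy-3,5-dimethoxyphenyl and gives no change at the digits printed from compound 3 to compound 4 (within the scatter). This position therefore takes a second methoxy with the hydroxy group kept, and the number shows no step beyond the scatter. The compounds shown leave open whether an amine or a carboxylic acid at this position would also leave the number level with compound 4. No measurement at hand accounts for this result.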